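Benzimidazole in place of furan on a weakly active core

This account rests on a few compounds, and the source may have more. Where it says the series, first, only, none or still open, it means among the compounds named here.

Measured compounds:
compound 1, `N#Cc1ccc(N2CCc3cc(-c4cnc5ccccc5c4)ccc3C2)cc1C(F)(F)F`, 25900 nM;
compound 2, `CCN(c1ccc(C#N)c(Cl)c1)c1cc(-c2ccoc2)ccc1C`, > 30000 nM;
compound 3, `CCN(c1ccc(C#N)c(Cl)c1)c1cc(-c2cnc3ccccc3c2)ccc1C`, "not determined" (no result reported).

In a functional assay on CWR22R cells (Homo sapiens) for antiproliferative activity, read by CCK-8 assay, with a stated time of 6 days (on this read-out higher numbers stand for weaker inhibition and lower numbers for stronger inhibition), compound 2 gives only > 30000 nM, a limit of the assay rather than a number. Among the three values shown, compound 2 stands at the limit of > 30000 nM in this assay, at which 1 of the 3 values shown sits, while compound 1, on a different core, gives 25900 nM. Compound 4, `CCN(c1ccc(C#N)c(Cl)c1)c1cc(-n2cnc3ccccc32)ccc1C`, differs from compound 2 by 1H-benzimidazol-1-yl in place of furan-3-yl on an aromatic carbon. Among the measured compounds shown here, no measured step informs this change. The estimate for compound 4 puts the step at an at least 1.5-fold lower number from compound 2 to compound 4 (0.17 log units; that floor lies within the scatter), which is expected to be no more than a modest move toward stronger inhibition. Compound 4 is estimated at 20000 nM, with a likely range from 5000 nM to 60000 nM.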

Compound 4, half-maximal inhibitory concentration: 3040 nM
Compound 4: middle estimate off by 6.6-fold (0.82 log units), on the high side; the measured number lies below the stated range.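

At this aromatic carbon, para to a methyl group, the shared core responds to the group it carries in this assay, where 1H-benzimidazol-1-yl in place of furan-3-yl gives an at least 9.8-fold lower number from compound 2 to compound 4 (0.99 log units; beyond the scatter) on the shared core. The earlier compounds shown here offered no step at this position, so this is its first reading. The size is only a floor, since compound 2 stands at a limit: the limit of > 30000 nM in this assay, at which 1 of the 4 values shown sits.

The compounds shown do not separate the added six-membered aromatic ring of carbon only from the nitrogen atoms of the entering group. From the compounds shown here alone, how an amine or a carboxylic acid would fare on this carbon also stays open.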